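The source may hold more compounds than are shown below. What is called first, only, known or untested is meant among the compounds shown, and "the series" means these compounds.

In a functional assay on DU-145 cells (Homo sapiens) for inhibition, read by trypan blue exclusion, with a stated time of 96 h (on this read-out higher numbers stand for weaker inhibition of growth and lower numbers for stronger inhibition of growth), compound 1 `O=C(/C(=C\c1ccc([N+](=O)[O-])c(O)c1)SCc1ccc(Br)cc1)c1ccc(Br)cc1` gives 10000 nM and compound 2 `O=C(/C(=C\c1ccc(O)cc1)S(=O)(=O)Cc1ccc(Cl)c(Cl)c1)c1ccc(Cl)cc1` gives 10000 nM; compound 3 `O=C(/C(=C\c1ccc2ccccc2n1)SCc1ccc(F)cc1)c1ccc(Br)cc1` gives 25000 nM. Compound 2 therefore stands level with compound 1 within the scatter, the two sharing the lowest number of the three, while compound 3 returns a higher number that lies beyond the scatter. Compound 4 `O=C(/C(=C\c1ccc(F)cc1C(F)(F)F)S(=O)(=O)Cc1ccc(Cl)c(Cl)c1)c1ccc(Cl)cc1` differs from compound 2 in one place: 4-fluoro-2-(trifluoromethyl)phenyl in place of 4-hydroxyphenyl on a double-bonded chain carbon bound to a double-bonded chain carbon. Among the compounds with values here, no step between measured compounds covers this change, so the expectation rests on the narrow spread of the three values. In this assay the step from compound 2 to compound 4 is expected to be small, at most a slight move toward weaker inhibition, so a 1.5-fold higher number from compound 2 to compound 4 (0.18 log units; within the scatter) is estimated. Compound 4 is expected to give about 15000 nM, with a range from 5000 nM to 50000 nM.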

Compound 4, concentration for 50% growth inhibition: 1000 nM
Compound 4: middle estimate off by 15-fold (1.18 log units), on the high side, outside the stated range (below it).
By their numbers in this assay, from the lowest: compound 4; then compounds 1 and 2 (each within the scatter of the next); then compound 3.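

In this assay the position on a double-bonded chain carbon bound to a double-bonded chain carbon proves responsive: 4-fluoro-2-(trifluoromethyl)phenyl in place of 4-hydroxyphenyl gives a 10-fold lower number from compound 2 to compound 4 (1.00 log units; beyond the scatter) in the direction of stronger inhibition of growth, a step beyond the scatter. Within the data shown here, the earlier compounds offered no single-place step, so this is the first reading of any change here. Nothing available accounts for the step.

The fluoro and trifluoromethyl groups enter together, leaving open which of them matters. On these data alone, how an amine at this position would read in this assay also stays open.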